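Methoxy for chloro on the aryl piperazine dithiocarbamate

This account rests on a few compounds, and the source may have more. Where it says the series, first, only, none or still open, it means among the compounds named here.

Measured so far in a functional assay on MGC-803 cells (Homo sapiens) for antiproliferative activity, read by CCK-8 assay, with a stated time of 72 h, tested at 2 uM; on this read-out lower numbers stand for a weaker effect and higher numbers for a stronger effect at the one concentration tested:
- compound 1, `Nc1ccccc1NC(=O)c1ccc(CSC(=S)N2CCN(c3ccc(Cl)cc3)CC2)cc1`: 15%
- compound 2, `Nc1ccccc1NC(=O)c1ccc(CSC(=S)N2CCc3ccccc32)cc1`: 44%
- compound 3, `CN(C(=S)SCc1ccc(C(=O)Nc2ccccc2N)cc1)c1cccnc1`: 46.1%

Compound 1 stands lowest of the three numbers; compound 2 and compound 3 both lie beyond the scatter above it, while the step of a number 2.1 percentage points higher from compound 2 to compound 3 (within the scatter) is within the scatter. Compound 4, `COc1ccc(N2CCN(C(=S)SCc3ccc(C(=O)Nc4ccccc4N)cc3)CC2)cc1`, differs from compound 1 by methoxy in place of chloro on an aromatic carbon. Within the data shown here, no measured pair shares this change: the one step in hand alters the group on the thiocarbonyl carbon, not the substituent on the 4-chlorophenyl ring, so it does not bear on this step. Without a comparable precedent, the expected step of a number 7 percentage points higher from compound 1 to compound 4 (within the scatter) is none beyond the scatter. Compound 4 is estimated at 22% in this assay, within 6% to 42%.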

Compound 4, a percentage reported as inhibition, at one concentration (the size of the read-out at that concentration, not a potency): 25.3%
Compound 4: the middle estimate sits 3.3 percentage points below what was measured; the measured number falls inside the stated range.
By their numbers in this assay, from the lowest: compound 1; then compound 4; then compounds 2 and 3 (each within the scatter of the next).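

In this assay, among these compounds, the change from 4-chlorophenyl to 4-methoxyphenyl gives a number 10.3 percentage points higher from compound 1 to compound 4 (beyond the scatter) and so shows, for the first time, that the substituent on this aromatic carbon, para to a large group, can shift the read-out, though only modestly. Nothing at hand accounts for this step. The compounds shown leave open how an amine, a nitrile or a hydrogen at this position would compare with chloro and methoxy, and whether the step would hold at other concentrations.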